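A few compounds are considered here, and "the series" means these few. Any claim that something is new, unique, unknown or untested is made for them only; others in the source may bear on it.

Compound 1 `CCC(CC)Nc1nc(C)c(-c2ccc(Cl)cc2Cl)nc1C`: 0.483 h
Compound 2 `CCc1nc(-c2ccc(Cl)cc2Cl)c(CC)nc1NC(C1CC1)C1CC1`: 0.183 h

In an in vitro ADME assay on microsomes (Homo sapiens) for metabolic stability (a higher number here means that the compound lasts longer, a lower number that the compound disappears faster), compound 1 gives 0.483 h and compound 2 gives the lower number of the two at 0.183 h. The gap between these two numbers lies beyond the scatter. Compound 3 `CCCN(CCN(C)C)c1nc(CC)c(-c2ccc(Cl)cc2Cl)nc1CC` has not yet been measured. It carries (2-(dimethylamino)ethyl)(propyl)amino in place of the (dicyclopropylmethyl)amino of compound 2 on an aromatic carbon ((2-(dimethylamino)ethyl)(propyl)amino in place of (dicyclopropylmethyl)amino on an aromatic carbon). Among the measured compounds shown here, no measured pair shows a change of this kind, so no shift beyond the scatter is expected in this assay. The estimated step is a 1.4-fold higher number from compound 2 to compound 3 (0.14 log units; within the scatter). Compound 3 is expected at 0.25 h, within an estimated range from 0.09 h to 0.7 h.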

Compound 3, half-life: 0.0833 h
Beside the measured number, compound 3's estimate is 3.0-fold (0.48 log units) above it; the whole stated range lies above it.
By their numbers in this assay, from the lowest: compound 3; then compound 2; then compound 1.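

In this assay, the group on this aromatic carbon moves the read-out: replacing (dicyclopropylmethyl)amino with (2-(dimethylamino)ethyl)(propyl)amino gives a 2.2-fold lower number from compound 2 to compound 3 (0.34 log units; beyond the scatter). This single change removes both three-membered rings and the hydrogen-bond donor, and it adds a second nitrogen and an open chain. No measurement available here explains the step. Which of these differences carries the step remains open. So does whether a chain ending in a hydroxyl group instead of dimethylamino would give a similar half-life at this position.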